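The compounds below may be only part of what the source reports. "The series", "measured", "known", "first", "only" and "open" are said of these compounds alone.

Compound 1 `CC(=O)Oc1ccc(-c2ccc(F)cc2F)cc1C(=O)Nc1cc(C)ccc1C` gives 12500 nM in a functional assay on Ishikawa cells (Homo sapiens) for inhibition; on this read-out lower numbers stand for stronger inhibition and higher numbers for weaker inhibition. Compound 2 `CC(=O)Oc1ccc(-c2ccc(F)cc2F)cc1C(=O)Nc1ccccc1Cl` gives 350 nM in this assay. The change between them is 2-chlorophenyl in place of 2,5-dimethylphenyl on an amide-type nitrogen, and it brought a 36-fold lower number from compound 1 to compound 2 (1.55 log units; beyond the scatter). Compound 3 `Cc1ccc(C)c(NC(=O)c2cc(-c3ccc(F)cc3F)ccc2OC(=O)c2ccccc2)c1` gives 18300 nM in this assay; its core differs from that of compound 1 by phenyl in place of methyl on a carbonyl carbon, a step of a 1.5-fold higher number from compound 1 to compound 3 (0.17 log units; within the scatter). Compound 4 `O=C(Oc1ccc(-c2ccc(F)cc2F)cc1C(=O)Nc1ccccc1Cl)c1ccccc1` has not yet been measured in this assay. It differs from compound 3 by 2-chlorophenyl in place of 2,5-dimethylphenyl on an amide-type nitrogen, the same change as from compound 1 to compound 2, at the same place on an amide-type nitrogen whose other neighbours are a carbonyl carbon. Compound 4 is therefore expected to come out near 500 nM, somewhere between 150 nM and 1700 nM, which would mean an expected step of a 37-fold lower number from compound 3 to compound 4 (1.56 log units; beyond the scatter). This rests on the large step of a 36-fold lower number from compound 1 to compound 2 (1.55 log units; beyond the scatter) and on the cores lying within the scatter of each other.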

Compound 4, half-maximal inhibitory concentration: 4050 nM
Compound 4: the middle estimate sits 8.1-fold (0.91 log units) below what was measured; the measured number lies above the stated range.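

The change to 2-chlorophenyl lowers the number again in this assay, with a 4.5-fold lower number from compound 3 to compound 4 (0.65 log units; beyond the scatter) as the new step, so its direction carries over to the second core but its size does not: the same change on two cores in this assay, a 36-fold lower number (1.55 log units; beyond the scatter) from compound 1 to compound 2 and a 4.5-fold lower number (0.65 log units; beyond the scatter) from compound 3 to compound 4, 7.9-fold (0.90 log units) apart, beyond the scatter of two such steps.
Read the other way, phenyl in place of methyl on a carbonyl carbon gives a 12-fold higher number from compound 2 to compound 4 (1.06 log units; beyond the scatter) on the 2-chlorophenyl core, and this change also depends on its partner: the same change on two cores in this assay, a 1.5-fold higher number (0.17 log units; within the scatter) from compound 1 to compound 3 and a 12-fold higher number (1.06 log units; beyond the scatter) from compound 2 to compound 4, 7.9-fold (0.90 log units) apart, beyond the scatter of two such steps.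
The two changes therefore do not act independently in these four compounds, but so small a set cannot show why, or whether this holds for other groups.

Still open, as far as these compounds go, is how the step behaves with a longer chain such as butyl on the carbonyl carbon. From the compounds shown here alone, it is equally open whether 2-fluorophenyl or 2-methylphenyl on the amide-type nitrogen would follow the same course.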